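From 2-nitrobenzyl to 2-bromobenzyl on the shared core

A few compounds are considered here, and "the series" means these few. Any claim that something is new, unique, unknown or untested is made for them only; others in the source may bear on it.

In a functional assay on SW-620 cells (Homo sapiens) for cytotoxicity, read by MTT assay, with stated times of 4 h and 72 h, tested at 5 uM (on this read-out higher numbers stand for weaker inhibition and lower numbers for stronger inhibition), compound 3 (`Cc1cc(Nc2ccc(C(=O)/C=C/c3ccc4ccccc4c3)cc2)n2nc(SCc3ccccc3[N+](=O)[O-])nc2n1`) gives 960 nM and compound 2 (`Cc1ccc(CSc2nc3nc(C)cc(Nc4ccc(C(=O)/C=C/c5ccc6ccccc6c5)cc4)n3n2)cc1`) gives 880 nM, so the two stand level, a 1.1-fold higher number from compound 2 to compound 3 (0.04 log units; within the scatter). Compound 1 (`Cc1cc(Nc2ccc(C(=O)/C=C/c3ccc4ccccc4c3)cc2)n2nc(SCc3cccc(Br)c3)nc2n1`) gives 270 nM, the lowest number of the three. Compound 4 (`Cc1cc(Nc2ccc(C(=O)/C=C/c3ccc4ccccc4c3)cc2)n2nc(SCc3ccccc3Br)nc2n1`) is not yet measured. It carries bromo in place of nitro on an aromatic carbon, ortho to a large group: bromo in place of nitro on an aromatic carbon. Among the compounds with values here, no measured step makes this exact exchange. The nearest is a 3.6-fold higher number from compound 1 to compound 3 (0.55 log units; beyond the scatter), with 2-nitrophenyl in place of 3-bromophenyl, and a 3.3-fold higher number from compound 1 to compound 2 (0.51 log units; beyond the scatter) is of similar size. Bromo in compound 1 sits differently, so only part of that gap is expected to return. In this assay a small move to a lower number is expected, a 1.9-fold lower number from compound 3 to compound 4 (0.28 log units; within the scatter). For compound 4 the estimate is 500 nM, with an expected range of 210 nM to 1100 nM.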

Compound 4, half-maximal inhibitory concentration: 420 nM
Beside the measured number, compound 4's estimate is 1.2-fold (0.08 log units) above it; low and high end bracket the measured number.
By their numbers in this assay, from the lowest: compounds 1 and 4 (each within the scatter of the next); then compounds 2 and 3 (each within the scatter of the next).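

In this assay, within the data shown here, bromo in place of nitro on the aromatic carbon, ortho to a large group, gives a 2.3-fold lower number from compound 3 to compound 4 (0.36 log units; beyond the scatter) and is the first single-group exchange read at this place. The 2-bromophenyl also separates from 4-methylphenyl, with a 2.1-fold lower number from compound 2 to compound 4 (0.32 log units; beyond the scatter), whereas moving bromo from the 3-bromophenyl to the 2-bromophenyl gives only a 1.6-fold higher number from compound 1 to compound 4 (0.19 log units; within the scatter), so these two bromo compounds stand level. Nothing at hand bears on the reason for these steps.

Open, from the compounds shown here alone, is how an amine or a methoxy group in the same place, ortho to a large group, would compare with bromo and nitro. Also open, going by these compounds, is whether a longer chain in place of the benzyl link would keep the values of the two bromo compounds.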